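Aryl variation at the benzyloxy position in a phenoxyethylamine series

The source may report more compounds than this note shows. Statements on the series, on what has been measured and on what is new or still open speak of the compounds shown alone.

Measured compounds:
compound 1 `COc1cccc(OC)c1OCCNCCOc1ccccc1OCc1ccccc1Cl` gives 0.251 nM
compound 2 `COc1cccc(OC)c1OCCNCCOc1ccccc1OCc1ccc(C)cc1` gives 0.0631 nM

Both compounds share the same core and differ only in the aromatic group carried on a saturated chain carbon bound to an oxygen on an aromatic ring. Among the compounds with values here, in an assay on CHO cells for displacement of a labelled ligand from Alpha-1D adrenergic receptor (Homo sapiens) (a lower number here means a stronger inhibitor, a higher number a weaker inhibitor), compound 1 stands at the higher of the two numbers; the only neighbour in the set is compound 2, reached by a 4.0-fold lower number from compound 1 to compound 2 (0.60 log units; beyond the scatter), a shift judged beyond the scatter.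

The next compound, compound 3 `COc1cccc(OC)c1OCCNCCOc1ccccc1OCc1ccc([N+](=O)[O-])cc1`, has not yet been measured in this assay. Against compound 1 it changes as follows: 4-nitrophenyl in place of 2-chlorophenyl on a saturated chain carbon bound to an oxygen on an aromatic ring

Within the data shown here, the single measured step that bears on this change is the one from compound 1 to compound 2, in which a group on the same chain carbon was exchanged and the number fell modestly. Among the measured compounds shown here, no measured step covers the 4-nitrophenyl group itself, so its effect is taken only by analogy with that step. For compound 3 the expectation is therefore a modest downward move, a 1.9-fold lower number from compound 1 to compound 3 (0.29 log units; within the scatter), with room for no change.

Compound 3 is estimated at 0.13 nM in this assay, within a range of 0.04 nM to 0.4 nM.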

Compound 3, inhibition constant: 0.0501 nM
Beside the measured number, compound 3's estimate is 2.6-fold (0.41 log units) above it; low and high end bracket the measured number.
By their numbers in this assay, from the lowest: compounds 3 and 2 (each within the scatter of the next); then compound 1.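

In this assay 4-nitrophenyl in place of 2-chlorophenyl on a saturated chain carbon bound to an oxygen on an aromatic ring gives a 5.0-fold lower number from compound 1 to compound 3 (0.70 log units; beyond the scatter) and so provides a second replacement of the 2-chlorophenyl group that ends beyond the scatter, after the 4-methylphenyl group seen earlier. Nitro in place of methyl on an aromatic carbon gives a 1.3-fold lower number from compound 2 to compound 3 (0.10 log units; within the scatter) and so the two groups are not told apart at this position, which leaves compound 1 as the only one of the three standing apart from the others. Nothing in hand offers a reason for either step.

Whether the lower numbers go with the loss of the chlorine or with the groups that enter stays open, as the compounds shown include neither a 4-chlorophenyl nor an unsubstituted phenyl group at this place. Also open, on these data alone, is how far the tolerance for different groups extends, for instance to a 4-aminophenyl or a 4-carboxyphenyl group, and how this series reads on other adrenergic receptors.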